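Swapping Piperazine for Piperidine on Compound 1

A few compounds are considered here, and "the series" means these few. Any claim that something is new, unique, unknown or untested is made for them only; others in the source may bear on it.

The account begins with compound 1 `COc1ccccc1-c1ccc2cnc(Nc3ccc(N4CCN(C[C@H](C)O)CC4)cc3)nn12` and its reading in an in vitro ADME assay on microsomes from liver (Canis lupus familiaris, strain beagle) for metabolic stability, using NADPH, with a stated time of 10 min, tested at 0.5 uM; a higher number here means that the compound lasts longer, a lower number that the compound disappears faster. For compound 1 this assay reports only a limit, > 0.666 h, so where it truly stands is not known. Compound 1 sits at the limit of > 0.666 h in this assay, at which 1 of the 3 values shown sits. Two companions share its core. Compound 2 `COc1ccccc1-c1ccc2cnc(Nc3cccc(N4CCN(C)CC4)c3)nn12` gives 0.0833 h in this assay, and compound 3 `COc1ccccc1-c1ccc2cnc(Nc3cccc(N4CCN(C[C@H](C)O)CC4)c3)nn12` gives 0.15 h. Among the compounds with values here, the single step between them, a 1.8-fold higher number from compound 2 to compound 3 (0.26 log units; within the scatter), concerns a change at the piperazine nitrogen and not at the ring itself.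

Compound 4 `COc1ccccc1-c1ccc2cnc(Nc3ccc(C4CCN(C[C@H](C)O)CC4)cc3)nn12` differs from compound 1 in one place: 1-(2-hydroxypropyl)piperidin-4-yl in place of 4-(2-hydroxypropyl)piperazin-1-yl on an aromatic carbon. Within the data shown here, no measured step covers this kind of change, and the one step that was measured is within the scatter, so nothing in the data points to a direction. The expectation is therefore a step of no size beyond the scatter, a step that the limit leaves unreadable from compound 1 to compound 4. Compound 4 is thus estimated to give 0.7 h in this assay, with a range from 0.3 h to 1.6 h.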

Compound 4, half-life: > 0.666 h
Compound 4: a limit, no number (the forecaster's own chance of this, stated with the estimate: 50%); the middle value does not contradict the limit.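

Within the data shown here, compound 1 and compound 4 each give only a limit in this assay, not a number, so no step between them can be read: the limit of > 0.666 h in this assay, at which 2 of the 4 values shown sit. The compounds shown leave open how long either lasts past that limit, and whether 1-(2-hydroxypropyl)piperidin-4-yl in place of 4-(2-hydroxypropyl)piperazin-1-yl changes the half-life at all.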